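Hydrogen in place of methyl on an amine nitrogen

This account rests on a few compounds, and the source may have more. Where it says the series, first, only, none or still open, it means among the compounds named here.

In a physicochemical assay for solubility, measured as kinetic solubility (on this read-out higher numbers stand for higher solubility and lower numbers for lower solubility), compound 1 `Cc1ccc(S(=O)(=O)Nc2ccc(CN(C)[C@@H]3CCN(C(=O)c4cccc(Cl)c4)C3)cc2)cc1` gives 28000 nM and sits within the scatter of both other measured compounds. Compound 3 `Cc1ccc(S(=O)(=O)Nc2ccc(CN(C)[C@H]3CCN(C(=O)c4cccc(Cl)c4)C3)cc2)cc1` gives 27000 nM and compound 2 `COc1ccc(S(=O)(=O)Nc2ccc(Cn3cc4c(n3)CN(C(=O)c3cccc(Cl)c3)C4)cc2)cc1` gives 19000 nM on the same read-out.

Compound 4 `Cc1ccc(S(=O)(=O)Nc2ccc(CN[C@@H]3CCN(C(=O)c4cccc(Cl)c4)C3)cc2)cc1` has not yet been measured. Set against compound 1 it shows hydrogen in place of methyl on an amine nitrogen with hydrogen in place of methyl on an amine nitrogen whose other neighbours are a saturated chain carbon and a saturated ring carbon.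

Among the measured compounds shown here, the one measured step, which is a 1.0-fold lower number from compound 1 to compound 3 (0.02 log units; within the scatter) and stays within the scatter, speaks only loosely to this change because of the fact that compounds 1 and 3 differ only in the configuration as drawn and no measured step alters the methyl. With compound 1 at 28000 nM as the closest anchor, no step beyond the scatter is expected in this assay and no direction is favoured. The estimated step is no change at the digits printed from compound 1 to compound 4 (within the scatter) and nothing larger is expected. Compound 4 is expected at 28000 nM with an estimated range from 14000 nM to 56000 nM on this read-out.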

Compound 4, solubility: 75000 nM
For compound 4 the middle estimate is 2.7-fold (0.43 log units) below the measured one, and the stated range ends below it.
By their numbers in this assay, from the lowest: compounds 2, 3 and 1 (each within the scatter of the next); then compound 4.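

In this assay, exchanging methyl for hydrogen on this amine nitrogen gives a step that the earlier comparison did not: a 2.7-fold higher number from compound 1 to compound 4 (0.43 log units; beyond the scatter). Among the compounds shown here, this step is modest but lies beyond the scatter, whereas the only earlier step stayed within it: a 1.0-fold lower number from compound 1 to compound 3 (0.02 log units; within the scatter). So the result shows that this amine nitrogen, whose other neighbours are a saturated chain carbon and a saturated ring carbon, is a place where the number can respond to the loss of a single carbon, which the earlier pair could not reveal since it left the methyl in place: the fact that compounds 1 and 3 differ only in the configuration as drawn.

This rests on a single pair, so the compounds shown do not tell why the number rises, or whether the same exchange would give a similar step in the configuration drawn for compound 3. They also leave open how the number would respond to an ethyl group, a longer chain or an acetyl group on this nitrogen, and so whether the step follows the size of the group or is particular to the exchange of methyl for hydrogen.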